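Replacing ethoxycarbonyl with hydroxy on the side chain

The compounds below may be only part of what the source reports. "The series", "measured", "known", "first", "only" and "open" are said of these compounds alone.

In an ADME assay on L929 cells (Mus musculus) for cytotoxicity, read by resazurin assay, with a stated time of 48 h (a higher number here means that more compound is tolerated, a lower number that less compound is tolerated), compound 1 `C#CCn1c2ccc([N+](=O)[O-])cc2c(=O)n1Cc1ccccc1` gives 195000 nM. Compound 2 `O=C(O)CCn1c2ccc([N+](=O)[O-])cc2c(=O)n1Cc1ccccc1` gives > 256000 nM, which is a limit of the assay and not a number. Compound 3 `CCOC(=O)CCCn1c2ccc([N+](=O)[O-])cc2c(=O)n1Cc1ccccc1` gives 78100 nM, the lower of the two actual numbers, so it is the least tolerated of the three.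

Compound 4 `O=c1c2cc([N+](=O)[O-])ccc2n(CCCO)n1Cc1ccccc1` has not yet been measured. It differs from compound 3 in one place: hydroxy in place of ethoxycarbonyl on a saturated chain carbon, three bonds along the chain from an aromatic nitrogen. This puts hydroxy in place of ethoxycarbonyl on a saturated chain carbon, three bonds along the chain from an aromatic nitrogen.

Among the measured compounds shown here, two measured steps bear on this change, and each arrives at the ethoxycarbonyl compound from a compound without that group: a 2.5-fold lower number from compound 1 to compound 3 (0.40 log units; beyond the scatter), and an at least 3.2-fold lower number from compound 2 to compound 3 (0.51 log units; beyond the scatter). Neither partner carries hydroxy, so they offer only a rough guide. Losing ethoxycarbonyl is therefore expected to reverse part of that fall in this assay, and the expected change is a 2.0-fold higher number from compound 3 to compound 4 (0.31 log units; beyond the scatter). For compound 4 the estimate is 160000 nM, with an expected range from 75000 nM to 270000 nM.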

Compound 4, concentration lethal to 50% of the cells: > 256000 nM
Compound 4: a limit, no number; the forecaster's own chance of this, stated with the estimate: 20%; at least 1.6-fold (0.20 log units) between middle value and limit.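

In this assay compound 4 gives > 256000 nM, which is a limit of the assay and not a number. Hydroxy in place of ethoxycarbonyl gives an at least 3.2-fold higher number from compound 3 to compound 4 (0.51 log units; beyond the scatter), so compound 3 now stands below a third partner, while the comparison with the ethynyl compound gives an at least 1.3-fold higher number from compound 1 to compound 4 (0.11 log units; that floor lies within the scatter), which does not separate the two. The step between compound 2 and compound 4 cannot be read: the limit of > 256000 nM in this assay, at which 2 of the 4 values shown sit.

As far as these compounds go, how much compound is tolerated in compound 2 and compound 4 stays unknown, so the order among the three compounds without ethoxycarbonyl remains unsettled. An amine in place of ethoxycarbonyl, or a longer chain carrying hydroxy, would show whether the lower number belongs to ethoxycarbonyl alone.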